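Working notes: fluoro in place of hydrogen on the phenyl

The compounds below may be only part of what the source reports. "The series", "measured", "known", "first", "only" and "open" are said of these compounds alone.

Three compounds of this series carry numbers in a functional assay on MGC-803 cells (Homo sapiens) for antiproliferative activity, read by MTT assay; on this read-out higher numbers stand for weaker inhibition and lower numbers for stronger inhibition. Compound 1 `COc1ccccc1NC(=O)Nc1cccc(CNc2ncnc3ccccc23)c1` gives 39300 nM. Compound 2 `CC(C)(C)c1ccc(NC(=O)Nc2cccc(CNc3ncnc4ccccc34)c2)cc1` gives 7470 nM; the step of a 5.3-fold lower number from compound 1 to compound 2 (0.72 log units; beyond the scatter) is the only one measured so far between compounds that differ in a single place. Compound 3 `COc1cc2ncnc(NCc3cccc(NC(=O)Nc4ccccc4)c3)c2cc1OC` gives 10000 nM, the second highest of the three numbers; compound 2 lies within the scatter of it, while compound 1 stands beyond the scatter on the higher side.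

Compound 4 `COc1cc2ncnc(NCc3cccc(NC(=O)Nc4ccc(F)cc4)c3)c2cc1OC` has not yet been measured. It differs from compound 3 by fluoro in place of hydrogen on an aromatic carbon. For the measured compounds named here, no measured step puts fluoro in place of hydrogen; the only step touching the phenyl on the amide-type nitrogen is a 5.3-fold lower number from compound 1 to compound 2 (0.72 log units; beyond the scatter), a modest change that exchanged one substituted phenyl for another. A single fluoro is a smaller alteration than that exchange, so for compound 4 in this assay no step beyond the scatter is expected in either direction, with at most a slight lowering. Compound 4 is therefore estimated at 8000 nM, with a range from 3000 nM to 20000 nM. The expected step is a 1.3-fold lower number from compound 3 to compound 4 (0.10 log units; within the scatter).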

Compound 4, half-maximal inhibitory concentration: 42100 nM
The estimate for compound 4 lay 5.3-fold (0.72 log units) below the measured number; measured number above the stated range.
By their numbers in this assay, from the lowest: compounds 2 and 3 (each within the scatter of the next); then compounds 1 and 4 (each within the scatter of the next).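

In this assay, fluoro in place of hydrogen is not a silent change at this place: a 4.2-fold higher number from compound 3 to compound 4 (0.62 log units; beyond the scatter), and this step lies beyond the scatter. Until now, the only measured step on this phenyl was a 5.3-fold lower number from compound 1 to compound 2 (0.72 log units; beyond the scatter), an exchange of one substituted phenyl for another on the core of compound 1, so the series had shown no effect of a single heavy atom on an aromatic carbon, para to a large group, and no step toward a higher number on the core of compound 3. Nothing available bears on why a single fluoro raises the number here.

The compounds shown do not tell whether the rise is particular to fluoro or would follow any group at this carbon; chloro, an amine or a carboxylic acid in the same place would separate these cases. They also leave open whether 4-(tert-butyl)phenyl, which gives the lower number in compound 2, would do the same on the core of compound 3.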